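A Chloro-to-Bromo Swap at the Cytotoxicity Limit

This account rests on a few compounds, and the source may have more. Where it says the series, first, only, none or still open, it means among the compounds named here.

In an ADME assay on Vero cells (Chlorocebus sabaeus) for cytotoxicity, read by CellTiter-Glo and ATP content, with a stated time of 72 h (a lower number here means that less compound is tolerated, a higher number that more compound is tolerated), compound 1 `Nc1c(C2=NCCN2)cnn1-c1ccc(Br)cc1` gives > 500000 nM as a limit of the assay and not a number. Compound 2 `Nc1c(C2=NCCCN2)cnn1-c1ccccc1` gives > 500000 nM as a limit as well. Compound 3 `Nc1c(C2=NCCCN2)cnn1-c1ccc(Cl)cc1` gives > 500000 nM as a limit too, so it has no exact place on the scale, and it shares that position with the other two compounds. For the measured compounds named here, the whole picture so far is the limit of > 500000 nM in this assay, at which 3 of the 3 values shown sit, and no tested compound has yet given a real number.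

Compound 4 `Nc1c(C2=NCCCN2)cnn1-c1ccc(Br)cc1` has bromo in place of chloro on an aromatic carbon and the change sits on a six-membered aromatic ring of carbon only, para to a large group. Going by the values given here, the only measured step that bears on this is a step that the two limits leave unreadable from compound 2 to compound 3 where chloro took the place of hydrogen, so there is no size to carry over. In this assay no step beyond the scatter is therefore expected, in either direction. The expected step is a step that the limit leaves unreadable from compound 3 to compound 4 and it should not be read as a real change. Compound 4 is estimated at about 600000 nM with an expected range from 300000 nM to 1200000 nM and the result will most likely be a limit again.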

Compound 4, half-maximal cytotoxic concentration: > 500000 nM
Compound 4 ended at the assay's limit (the forecaster's own chance of this, stated with the estimate: 90%); the middle value is on the limit's open side.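

No step can be read between compound 4 and compound 1, compound 2 or compound 3 in this assay, because each of these compounds gives only a limit of the assay and not a number: the limit of > 500000 nM in this assay, at which 4 of the 4 values shown sit.

The compounds shown leave open what concentration of any of them reaches the half-maximal cytotoxic effect, and whether hydrogen, chloro or bromo on the aromatic carbon makes any difference to it.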